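A furan-to-thiophene swap on a nucleoside

The source may report more compounds than this note shows. Statements on the series, on what has been measured and on what is new or still open speak of the compounds shown alone.

Compound 1 `C#Cc1cn([C@@H]2O[C@H](CO)[C@@H](O)[C@H]2O)c2ncnc(SC)c12`: 140 nM
Compound 2 `CNc1ncnc2c1c(-c1ccco1)cn2[C@@H]1O[C@H](CO)[C@@H](O)[C@H]1O`: 2570 nM

Both values come from a functional assay on A549 cells (Homo sapiens), read by MTT assay, with a stated time of 72 h; a higher number here means a weaker inhibitor, a lower number a stronger inhibitor. Compound 2 stands at the higher of the two numbers, 2570 nM, so it is the weaker inhibitor of the pair, and its gap to compound 1 lies beyond the scatter. The two compounds differ in more than one place, so this gap cannot be tied to any single structural change.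

Compound 3 `CNc1ncnc2c1c(-c1cccs1)cn2[C@@H]1O[C@H](CO)[C@@H](O)[C@H]1O` is compound 2 with thiophen-2-yl in place of furan-2-yl on an aromatic carbon. The rest of the structure stays the same, and each group is one five-membered aromatic ring with 1 hetero atom. For the measured compounds named here, no measured pair shows this exchange, so the only anchor is compound 2 at 2570 nM. In this assay, on these data alone, no step beyond the scatter is expected, and the direction remains open. The estimate corresponds to an expected small shift, a 1.3-fold lower number from compound 2 to compound 3 (0.11 log units; within the scatter). For compound 3 the estimated value is 2000 nM, with an expected range from 700 nM to 6000 nM.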

Compound 3, half-maximal inhibitory concentration: > 20000 nM
Compound 3: only a limit was reported; the forecaster's own chance of this, stated with the estimate: 8%; middle value at least 10-fold (1.00 log units) away from the limit.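

In this assay compound 3 gives > 20000 nM, which is a limit of the assay and not a number. Thiophen-2-yl in place of furan-2-yl on this aromatic carbon, two ring bonds from the ring nitrogen, gives an at least 7.7-fold higher number from compound 2 to compound 3 (0.89 log units; beyond the scatter), so this position responds to a change of a single ring atom, sulfur for oxygen, even though the two groups have the same heavy-atom, donor and acceptor counts and are each one five-membered aromatic ring with 1 hetero atom. The true size of this step stays unknown, and the figure gives only its lower bound, because the reading for compound 3 is capped: the limit of > 20000 nM in this assay, at which 1 of the 3 values shown sits.

The compounds shown leave open how other groups on this carbon would compare with furan-2-yl, for instance a phenyl ring, an aminomethyl group or a longer chain, and why the two rings part so sharply. Compound 1 differs from both others in more than one place, so it cannot settle whether the same exchange would have a similar effect on a different core.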